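A few compounds are considered here, and "the series" means these few. Any claim that something is new, unique, unknown or untested is made for them only; others in the source may bear on it.

In a functional assay on NCI-H460 cells (Homo sapiens) for antiproliferative activity (a lower number here means a stronger inhibitor, a higher number a weaker inhibitor), compound 1 (`COc1ccc(S(=O)(=O)Oc2ccccc2NC(=O)Nc2ccccc2)cc1`) reaches only a limit, > 10000 nM. Compound 2 (`COc1ccc(S(=O)(=O)Oc2ccccc2NC(=O)c2ccccn2)cc1`) gives a measured 300 nM. Compound 3 (`COc1ccc(S(=O)(=O)Oc2ccccc2NC(=O)c2ccc3ncccc3c2)cc1`) also stands only at a limit, > 10000 nM. Compound 4 (`COc1ccc(S(=O)(=O)Oc2ccccc2NC(=O)c2ccc(F)cc2)cc1`) carries 4-fluorophenyl in place of quinolin-6-yl on a carbonyl carbon. Among the measured compounds shown here, no measured step brings in 4-fluorophenyl, so the guides are the changes at this same carbonyl carbon. These are an at least 33-fold lower number from compound 1 to compound 2 (1.52 log units; beyond the scatter) and an at least 33-fold higher number from compound 2 to compound 3 (1.52 log units; beyond the scatter), both large, so the group here can matter greatly in either direction. The expected result is an at least 4.0-fold lower number from compound 3 to compound 4 (0.60 log units; beyond the scatter), a modest gain that may not clear the limit. Compound 4 is estimated at 2500 nM, with an expected range from 300 nM to 10000 nM.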

Compound 4, half-maximal inhibitory concentration: 550 nM
Estimate against measurement, compound 4: 4.5-fold (0.66 log units) above; the range from low to high includes it.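

In this assay, a ring of carbon only can carry activity on this carbonyl carbon, with an at least 18-fold lower number from compound 3 to compound 4 (1.25 log units; beyond the scatter) and an at least 18-fold lower number from compound 1 to compound 4 (1.25 log units; beyond the scatter). Against pyridin-2-yl there is a 1.8-fold higher number from compound 2 to compound 4 (0.26 log units; within the scatter), so a ring nitrogen is not required for activity at this place. Both large steps are open-ended, each resting on a limit: the limit of > 10000 nM in this assay, at which 2 of the 4 values shown sit.

On these data alone, what remains open is what the fluorine itself contributes, set against plain phenyl. As far as these compounds go, it is also open whether a chlorine or a methoxy group in its place would hold the value.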